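The source may report more compounds than this note shows. Statements on the series, on what has been measured and on what is new or still open speak of the compounds shown alone.

Compound 1 `COc1ccc(C2=C(c3cc(OC)c(OC)c(OC)c3)C(=O)C(O)C2)cc1NC(=O)c1ccccc1` gives in an ADME assay on MIA PaCa-2 cells (Homo sapiens) for cytotoxicity, read by MTT assay, with a stated time of 72 h (a lower number here means a stronger inhibitor, a higher number a weaker inhibitor), the value > 100 ug/mL, which is a limit of the assay and not a number.
Compound 2 `COc1ccc(C2=C(c3cc(OC)c(OC)c(OC)c3)C(=O)C(O)C2)cc1` gives in this assay the value < 1 ug/mL, again a limit rather than a number.
Compound 3 `COc1ccc(C2=C(c3cc(OC)c(OC)c(OC)c3)C(=O)C(O)C2)cc1Cl` gives in this assay the value > 100 ug/mL, also a limit.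

Among the three values, compound 3 stands at the limit of > 100 ug/mL in this assay, at which 2 of the 3 values shown sit, so all that is known is that compound 3 is a weak inhibitor. Compound 2 alone sits at the limit of < 1 ug/mL in this assay, at which 1 of the 3 values shown sits. Compound 4 `COc1ccc(C2=C(c3cc(OC)c(OC)c(OC)c3)C(=O)C(O)C2)cc1OC(C)C` differs from compound 3 in one place: isopropoxy in place of chloro on an aromatic carbon.

For the measured compounds named here, two measured steps bear on this change. Replacing the benzamido of compound 1 by hydrogen gives an at least 100-fold lower number from compound 1 to compound 2 (2.00 log units; beyond the scatter), and replacing that hydrogen by chloro gives an at least 100-fold higher number from compound 2 to compound 3 (2.00 log units; beyond the scatter). The remaining step, a step that the two limits leave unreadable from compound 1 to compound 3, adds nothing readable. So the only potent compound is the one with a bare hydrogen at this carbon, while both compounds carrying a group there sit at the upper limit. Isopropoxy is another group at the same carbon, so the step of an at least 1.2-fold lower number from compound 3 to compound 4 (0.09 log units; that floor lies within the scatter) is expected to be none beyond the scatter, with compound 4 staying weak. For compound 4 the estimate is 80 ug/mL, with a likely range from 15 ug/mL to 150 ug/mL.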

Compound 4, half-maximal inhibitory concentration: > 100 ug/mL
Compound 4 was reported as a limit; the forecaster's own chance of this, stated with the estimate: 60%; at least 1.2-fold (0.09 log units) between middle value and limit.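

Compound 4 brings a third group to this aromatic carbon, ortho to a methoxy group, and in this assay putting isopropoxy in place of the hydrogen gives an at least 100-fold higher number from compound 2 to compound 4 (2.00 log units; beyond the scatter). Loss of potency at this carbon therefore no longer rests on chloro and benzamido alone, and it now also holds for a group joined to the ring through oxygen, with four heavy atoms where chloro has one. The steps among compounds 1, 3 and 4 cannot be read, so these three groups cannot be ranked against one another, and the compounds now fall into just two sets, one potent and one weak, each defined by a limit rather than a number: the limit of > 100 ug/mL in this assay, at which 3 of the 4 values shown sit.

Whether any group at this carbon keeps the potency of the bare hydrogen remains open, since a fluorine atom, a hydroxyl, a methyl and an amine are all absent from the compounds shown. Also open, on these data alone, is how far compounds 1, 3 and 4 lie from one another, and whether a carboxylic acid or a longer chain at this carbon would behave as they do.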